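The source may report more compounds than this note shows. Statements on the series, on what has been measured and on what is new or still open speak of the compounds shown alone.

Compound 1, `COc1cc(-n2cnc3ccc(-c4cccc(N)c4)cc32)cc(OC)c1OC`: 21 nM
Compound 2, `COc1cc(-n2cnc3ccc(-c4cccc(F)c4)cc32)cc(OC)c1OC`: 2490 nM
Compound 3, `COc1cccc(-c2ccc3ncn(-c4cc(OC)c(OC)c(OC)c4)c3c2)c1`: 3310 nM

In a functional assay on SGC-7901 cells (Homo sapiens) for antiproliferative activity, read by MTT assay, with a stated time of 72 h (a higher number here means a weaker inhibitor, a lower number a stronger inhibitor), compound 3 gives the highest of the three numbers. Compound 2 stands nearest, separated by a 1.3-fold higher number from compound 2 to compound 3 (0.12 log units; within the scatter), and compound 1 furthest, separated by a 160-fold higher number from compound 1 to compound 3 (2.20 log units; beyond the scatter). Compound 4, `COc1ccccc1-c1ccc2ncn(-c3cc(OC)c(OC)c(OC)c3)c2c1`, has the same atoms as compound 3, joined differently: 2-methoxyphenyl in place of 3-methoxyphenyl on an aromatic carbon. Among the measured compounds shown here, no measured step bears directly on this change. The steps of a 120-fold higher number from compound 1 to compound 2 (2.07 log units; beyond the scatter) and a 160-fold higher number from compound 1 to compound 3 (2.20 log units; beyond the scatter) are large, while a 1.3-fold higher number from compound 2 to compound 3 (0.12 log units; within the scatter) is within the scatter, and compound 4 keeps a methoxy group and no amino group, as compound 3 does. A step of a 1.1-fold lower number from compound 3 to compound 4 (0.04 log units; within the scatter) is therefore expected, within the scatter. Compound 4 is expected to give 3000 nM, in the range 1000 nM to 10000 nM.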

Compound 4, half-maximal inhibitory concentration: 5050 nM
Beside the measured number, compound 4's estimate is 1.7-fold (0.23 log units) below it; measured number inside the range.
By their numbers in this assay, from the lowest: compound 1; then compounds 2, 3 and 4 (each within the scatter of the next, the first and the last beyond it).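

Replacing 3-methoxyphenyl with 2-methoxyphenyl in this assay gives a 1.5-fold higher number from compound 3 to compound 4 (0.18 log units; within the scatter), so relocating the methoxy group on this ring makes no clear difference. Compound 4 also shows a 2.0-fold higher number from compound 2 to compound 4 (0.31 log units; beyond the scatter), a modest gap, and a 240-fold higher number from compound 1 to compound 4 (2.38 log units; beyond the scatter), which confirms that among these four compounds only compound 1, with its amino group, stands far apart. Nothing measured here explains that gap. Still open, from the compounds shown here alone, is whether the amino group's effect depends on where it sits on this ring, and whether a hydroxyl or methylamino group could take its place.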